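Alpha-hydroxy alkyl amide in place of the pyrazolylmethyl amide

The compounds below may be only part of what the source reports. "The series", "measured", "known", "first", "only" and "open" are said of these compounds alone.

Working notes on three measured amides and one open one. Compound 1 `Cc1ccc(C(=O)Nc2sc3c(c2C(N)=O)CCOC3)s1` carries a different core and gives 778 nM in an assay on cells for positive allosteric modulation of Cystic fibrosis transmembrane conductance regulator variant F508del (Homo sapiens), with stated times of 10 min and 7 s, in the presence of a further agent that is not named here; on this read-out lower numbers stand for an effect already at smaller amounts and higher numbers for an effect only at larger amounts of compound. Compound 2 `CC1(C)Cc2c(sc(NC(=O)c3ccccc3O)c2C(N)=O)C(C)(C)O1`, with the 2-hydroxyphenyl amide on the shared core, gives 4 nM. Compound 3 `CC1(C)Cc2c(sc(NC(=O)Cc3ccn[nH]3)c2C(N)=O)C(C)(C)O1` gives 136 nM; on the numbers shown it stands second highest of three, nearer to compound 1 than to compound 2. Going by the values given here, the one step that rests on a single change is a 34-fold higher number from compound 2 to compound 3 (1.53 log units; beyond the scatter). Compound 4 `CC1(C)Cc2c(sc(NC(=O)[C@@H](O)C(C)(C)C)c2C(N)=O)C(C)(C)O1` differs from compound 3 by 1-hydroxy-2,2-dimethylpropyl in place of (1H-pyrazol-5-yl)methyl on a carbonyl carbon. Among the compounds with values here, no measured step covers a 1-hydroxy-2,2-dimethylpropyl group on the carbonyl carbon; the step from compound 2 to compound 3 shows only how much the 2-hydroxyphenyl amide is worth, and compound 4 does not bring that group back. With nothing to fix the direction, the expected step is a 1.5-fold lower number from compound 3 to compound 4 (0.18 log units; within the scatter), small and uncertain in sign. Compound 4 is therefore estimated at 90 nM, between 15 nM and 500 nM, in this assay.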

Compound 4, half-maximal effective concentration: 2.7 nM
Estimate against measurement, compound 4: 33-fold (1.52 log units) above, and the stated range ends above it.
By their numbers in this assay, from the lowest: compounds 4 and 2 (each within the scatter of the next); then compound 3; then compound 1.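

On the shared core in this assay, a ring on the carbonyl carbon is not required for a low number: 1-hydroxy-2,2-dimethylpropyl, which has no ring, gives a 50-fold lower number from compound 3 to compound 4 (1.70 log units; beyond the scatter), although the two groups carry equal counts of heavy atoms, hydrogen-bond donors and hydrogen-bond acceptors. The open-chain group and the 2-hydroxyphenyl group are not told apart at this position, with a 1.5-fold lower number from compound 2 to compound 4 (0.17 log units; within the scatter), so the aromatic ring of compound 2 can be replaced here without a change beyond the scatter. No evidence on the cause of either step accompanies these results.

Going by these compounds, whether the hydroxyl and its defined stereocentre matter remains open; the opposite stereoisomer, or a methoxy group or an amine in place of the hydroxyl, would separate these points. On these data alone, how far the alkyl part can shrink is also open, with 1-hydroxyethyl as a smaller chain to read against compound 4.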